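Working notes: from compound 2 to compound 4

The source may report more compounds than this note shows. Statements on the series, on what has been measured and on what is new or still open speak of the compounds shown alone.

Of the compounds shown here, three of this set have been measured in a functional assay on HCT-116 cells (Homo sapiens) for inhibition, read by sulforhodamine B assay, with a stated time of 48 h, tested at 50 uM; on this read-out higher numbers stand for more inhibition of growth at the one concentration tested and lower numbers for less inhibition of growth. Compound 1 `COc1ccccc1/C=C/C(=O)/C=C/c1ccc(OCc2cn(CCOc3cc(=O)oc4ccccc34)nn2)c(OC)c1` gives 70%. Compound 2 `COc1cc(/C=C/C(=O)/C=C/c2cc(OC)c(OC)c(OC)c2)ccc1OCc1cn(CCCOc2cc(=O)oc3ccccc23)nn1` gives 76%, the highest of the three numbers; compound 1 lies within the scatter of it, so no order between these two is claimed. Compound 3 `COc1cc(/C=C/C(=O)/C=C/c2ccco2)ccc1OCc1cn(CCCCOc2cc(=O)oc3ccccc23)nn1` gives 47%, which is beyond the scatter below compound 2.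

Compound 4 `COc1cccc(/C=C/C(=O)/C=C/c2ccc(OCc3cn(CCCOc4cc(=O)oc5ccccc45)nn3)c(OC)c2)c1` has not yet been measured in this assay. Against compound 2 the change is 3-methoxyphenyl in place of 3,4,5-trimethoxyphenyl on a double-bonded chain carbon bound to a double-bonded chain carbon. For the measured compounds named here, no measured pair in the set differs in only this one place, so the size of the step has to be judged from the whole set rather than from a direct comparison. Compound 1, which also carries a phenyl with a single methoxy at the same end of the chain, sits within the scatter of compound 2, while compound 3 falls clearly lower.

On this basis a small downward step, most likely not beyond the scatter, is expected: a number 10 percentage points lower from compound 2 to compound 4 (within the scatter). Compound 4 is therefore expected to give about 66% in this assay, with a range from 48% to 82%.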

Compound 4, percent growth inhibition at one concentration: 55%
For compound 4 the middle estimate is 11 percentage points above the measured one; low and high end bracket the measured number.
By their numbers in this assay, from the lowest: compounds 3 and 4 (each within the scatter of the next); then compounds 1 and 2 (each within the scatter of the next).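

In this assay, for the compounds shown here, compound 2 and compound 4 form the only pair that differs in one place, and 3-methoxyphenyl in place of 3,4,5-trimethoxyphenyl on a double-bonded chain carbon bound to a double-bonded chain carbon gives a number 21 percentage points lower from compound 2 to compound 4 (beyond the scatter), so the number is sensitive to the group at this position. The group that enters has fewer heavy atoms and fewer hydrogen-bond acceptors than the group that leaves, but a single step cannot separate these differences or show which methoxy groups matter. Nothing at hand explains the change at this position.

Open, on these data alone, is how a phenyl carrying a hydroxyl, an amine or a carboxylic acid would read at this position, since only these two groups can be compared directly here. Also open, as far as these compounds go, is whether the same step would appear with a longer chain elsewhere in the shared core, and whether it would hold beyond the single concentration and single cell line of this assay.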